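Shortening the side chain on the shared core

The source may report more compounds than this note shows. Statements on the series, on what has been measured and on what is new or still open speak of the compounds shown alone.

Measured compounds:
Compound 1, `COC(C(=O)O)c1nn(Cc2cn3cc(OCC4CC4)c(Cl)cc3n2)c2ccccc2c1=O`: 23 nM
Compound 2, `CC(C)(C(=O)O)c1nn(Cc2cn3cc(OCC4CC4)c(Cl)cc3n2)c2ccccc2c1=O`: 7.7 nM
Compound 3, `CCC(C(=O)O)c1nn(Cc2cn3cc(OCC4CC4)c(Cl)cc3n2)c2ccccc2c1=O`: 5.6 nM

All three were tested in a functional assay on CHO cells for antagonist activity at sphingosine 1-phosphate receptor 2 (Homo sapiens), read by calcium flux; on this read-out lower numbers stand for stronger inhibition and higher numbers for weaker inhibition. Compound 3 gives the lowest number of the three, but only the gap to compound 1 is beyond the scatter: a 4.1-fold lower number from compound 1 to compound 3 (0.61 log units; beyond the scatter). Compound 2 sits close to it, since a 1.4-fold lower number from compound 2 to compound 3 (0.14 log units; within the scatter). The step from compound 1 to compound 2 is also clear: a 3.0-fold lower number from compound 1 to compound 2 (0.48 log units; beyond the scatter).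

Compound 4, `C[C@H](C(=O)O)c1nn(Cc2cn3cc(OCC4CC4)c(Cl)cc3n2)c2ccccc2c1=O`, is not yet measured. It differs from compound 3 in one place: 1-carboxyethyl in place of 1-carboxypropyl on an aromatic carbon. The side chain loses one carbon and the remaining stereocentre is defined.

Among the compounds with values here, no measured step probes this exact change. Within the data shown here, the steps that bear on it show that swapping methoxy for ethyl mattered, while moving between two small alkyl arrangements did not. A small alkyl group therefore seems to carry most of the effect, and a shorter chain is expected to change little: a 1.1-fold higher number from compound 3 to compound 4 (0.03 log units; within the scatter). Compound 4 is estimated at 6 nM, within 2 nM to 20 nM.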

Compound 4, half-maximal inhibitory concentration: 3.2 nM
The estimate for compound 4 lay 1.9-fold (0.27 log units) above the measured number, and the stated range covers the measured number.
By their numbers in this assay, from the lowest: compounds 4, 3 and 2 (each within the scatter of the next, the first and the last beyond it); then compound 1.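

In this assay, the 1-carboxyethyl group of compound 4 cannot be separated from the 1-carboxypropyl group of compound 3, since this step stays within the scatter (a 1.8-fold lower number from compound 3 to compound 4 (0.24 log units; within the scatter)). The same group does separate from the 1-carboxy-1-methylethyl group of compound 2 (a 2.4-fold lower number from compound 2 to compound 4 (0.38 log units; beyond the scatter)), which shows that this position can tell small alkyl arrangements apart, something the step between compound 2 and compound 3 could not show. The gap to the methoxy-bearing chain of compound 1 is the widest in the set (a 7.2-fold lower number from compound 1 to compound 4 (0.86 log units; beyond the scatter)), and no supporting data are available to explain any of these differences.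

Going by these compounds, the opposite stereocentre in the 1-carboxyethyl group remains open, as does the effect of the defined stereocentre itself. A longer chain such as 1-carboxybutyl, or plain carboxymethyl with no alkyl group on that carbon, is also untested among the compounds shown.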